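Trimming two methyl groups from a terminal piperidine

The source may report more compounds than this note shows. Statements on the series, on what has been measured and on what is new or still open speak of the compounds shown alone.

Measured in a physicochemical assay for permeability, using PAMPA; on this read-out higher numbers stand for higher permeability and lower numbers for lower permeability:

- compound 1 `Cc1ccc(C)c(-c2nc(CN3CCC(C(=O)NCCCN4C[C@H](C)C[C@H](C)C4)CC3)c(C)o2)c1`: "not determined" (no result reported)
- compound 2 `Cc1oc(-c2c(C)c(C)c(C)c(C)c2C)nc1CN1CCC(C(=O)NCCCN2C[C@H](C)C[C@H](C)C2)CC1`: 455 10^-6 cm/s
- compound 3 `Cc1ccccc1-c1nc(CN2CCC(C(=O)NCCCN3CC(C)(C)CC(C)(C)C3)CC2)c(C)o1`: > 1390 10^-6 cm/s (a limit, not a number)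

Compound 3 has no single number to its name, only a limit: it sits at the limit of > 1390 10^-6 cm/s in this assay, at which 1 of the 3 values shown sits. Compound 4 `Cc1ccccc1-c1nc(CN2CCC(C(=O)NCCCN3CCC(C)(C)CC3)CC2)c(C)o1` differs from compound 3 in one place, on a saturated chain carbon, three bonds along the chain from an amide-type nitrogen: a group of 8 heavy atoms (7 carbon, 1 nitrogen; one six-membered non-aromatic ring with 1 hetero atom) in place of a group of 10 heavy atoms (9 carbon, 1 nitrogen; one six-membered non-aromatic ring with 1 hetero atom), on a saturated chain carbon, three bonds along the chain from an amide-type nitrogen. The entering group is 4,4-dimethylpiperidin-1-yl. No measured step sizes this change, so only a small downward move in this assay is expected, hardly beyond the scatter. The expected change is an at least 1.3-fold lower number from compound 3 to compound 4 (0.14 log units; that floor lies within the scatter). For compound 4 the estimated value is 1000 10^-6 cm/s, with an expected range from 400 10^-6 cm/s to 2000 10^-6 cm/s.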

Compound 4, apparent permeability: 241 10^-6 cm/s
Beside the measured number, compound 4's estimate is 4.1-fold (0.62 log units) above it; the whole stated range lies above it.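

In this assay, within the data shown here, this is the first measured step at this place, on a saturated chain carbon, three bonds along the chain from an amide-type nitrogen: with 4,4-dimethylpiperidin-1-yl in place of the group of 10 heavy atoms, the result is an at least 5.7-fold lower number from compound 3 to compound 4 (0.76 log units; beyond the scatter). This change in the terminal ring therefore moves the read-out beyond the scatter. The true size of the step stays unknown because compound 3 stands at a limit, not a number: the limit of > 1390 10^-6 cm/s in this assay, at which 1 of the 4 values shown sits.

The compounds shown leave open how a plain piperidin-1-yl or a morpholin-4-yl group would read at this place. They also leave open whether the same step holds on the core of compound 2.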